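The source may report more compounds than this note shows. Statements on the series, on what has been measured and on what is new or still open speak of the compounds shown alone.

Working notes on the series in a functional assay on A2780 cells (Homo sapiens) for antiproliferative activity, read by resazurin assay, with a stated time of 72 h; a lower number here means a stronger inhibitor, a higher number a weaker inhibitor. Compound 1 `CN(C(=O)c1cc2c(Cc3ccccc3)n[nH]c2cc1O)c1ccco1` gives 2500 nM and compound 2 `CN(Cc1ccc(Br)cc1)C(=O)c1cc2c(Cc3ccccc3)n[nH]c2cc1O` gives 2800 nM, so compound 2 stands level with compound 1 within the scatter. Compound 3 `COc1cc(CN(C)C(=O)c2cc3c(Cc4ccccc4)n[nH]c3cc2O)ccc1Cl` differs from compound 2 on a saturated chain carbon bound to an amide-type nitrogen: 4-chloro-3-methoxyphenyl in place of 4-bromophenyl on a saturated chain carbon bound to an amide-type nitrogen. Cut one bond further out, this reads 4-bromobenzyl to 4-chloro-3-methoxybenzyl. Within the data shown here, only one measured step bears on this, and it is small: a 1.1-fold higher number from compound 1 to compound 2 (0.05 log units; within the scatter), with 4-bromobenzyl in place of furan-2-yl on the same nitrogen. Among the measured compounds shown here, no measured compound carries the 4-chloro-3-methoxyphenyl group, so the basis is thin. No step beyond the scatter is expected in this assay, and the expected change is a 1.1-fold lower number from compound 2 to compound 3 (0.05 log units; within the scatter). Compound 3 is estimated at 2500 nM, with an expected range of 1000 nM to 6000 nM.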

Compound 3, half-maximal inhibitory concentration: 4100 nM
Compound 3: the middle estimate sits 1.6-fold (0.21 log units) below what was measured; the range from low to high includes it.
By their numbers in this assay, from the lowest: compounds 1, 2 and 3 (each within the scatter of the next).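

In this assay, the place on a saturated chain carbon bound to an amide-type nitrogen accepts a second substituted phenyl group without a step beyond the scatter: 4-chloro-3-methoxyphenyl in place of 4-bromophenyl gives (a 1.5-fold higher number from compound 2 to compound 3 (0.17 log units; within the scatter)), and 4-chloro-3-methoxybenzyl in place of furan-2-yl on the amide-type nitrogen gives (a 1.6-fold higher number from compound 1 to compound 3 (0.21 log units; within the scatter)). The entering group carries a hydrogen-bond acceptor where 4-bromophenyl carries none, and this difference comes with no step beyond the scatter. No supporting measurement is available to explain these numbers.

From the compounds shown here alone, it remains open whether any group on this nitrogen can move the number beyond the scatter, for example an aminoethyl chain, a carboxylic acid or a longer alkyl chain. Going by these compounds, the contribution of the groups on the shared core also remains open, as they are the same in all three compounds.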